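The source may report more compounds than this note shows. Statements on the series, on what has been measured and on what is new or still open speak of the compounds shown alone.

Measured so far in a functional assay on MCF7 cells (Homo sapiens) for inhibition, read by MTT assay, with a stated time of 72 h; on this read-out higher numbers stand for weaker inhibition of growth and lower numbers for stronger inhibition of growth:
- compound 1 `O=S(=O)(NCCCCNCc1ccc(Br)cc1)c1cc(C(F)(F)F)cc(C(F)(F)F)c1`: 1500 nM
- compound 2 `O=S(=O)(NCCCNCc1ccc(Cl)cc1)c1cc(C(F)(F)F)cc(C(F)(F)F)c1`: 2400 nM
- compound 3 `CN(CCCNS(=O)(=O)c1cc(C(F)(F)F)cc(C(F)(F)F)c1)Cc1ccccc1`: 16000 nM

Compound 1 gives the lowest number of the three; compound 2 sits within the scatter of it (a 1.6-fold higher number from compound 1 to compound 2 (0.20 log units; within the scatter)), while compound 3 lies well apart (an 11-fold higher number from compound 1 to compound 3 (1.03 log units; beyond the scatter), and a 6.7-fold higher number from compound 2 to compound 3 (0.82 log units; beyond the scatter)).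

Compound 4 `COc1ccccc1CNCCCNS(=O)(=O)c1cc(C(F)(F)F)cc(C(F)(F)F)c1` is not yet measured in this assay. It differs from compound 1 by (2-methoxybenzyl)amino in place of ((4-bromobenzyl)amino)methyl on a saturated chain carbon, three bonds along the chain from a sulfonamide nitrogen. For the measured compounds named here, two measured steps bear on this. The step to compound 2 shows that shortening the chain and exchanging the 4-substituent of the benzyl ring leaves the number within the scatter. The steps to compound 3 show that exchanging the benzylamino group for benzyl(methyl)amino, which has no hydrogen-bond donor, raises the number considerably. Compound 4 keeps a benzylamino group with its hydrogen-bond donor, so the change is closer in kind to the step to compound 2 than to compound 3; a small to modest rise, if any, is expected.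

Compound 4 is estimated at 3500 nM (range 1500 nM to 9000 nM), a step of a 2.3-fold higher number from compound 1 to compound 4 (0.37 log units; beyond the scatter).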

Compound 4, concentration for 50% growth inhibition: 2600 nM
Estimate against measurement, compound 4: 1.3-fold (0.13 log units) above; measured number inside the range.
By their numbers in this assay, from the lowest: compounds 1, 2 and 4 (each within the scatter of the next); then compound 3.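

In this assay, the ring of the benzylamino group accepts 2-methoxyphenyl in place of 4-chlorophenyl without a change beyond the scatter (a 1.1-fold higher number from compound 2 to compound 4 (0.03 log units; within the scatter)), so the halogen-bearing rings of compounds 1 and 2 are not required at this level of activity. The exchange of ((4-bromobenzyl)amino)methyl for (2-methoxybenzyl)amino also stays within the scatter (a 1.7-fold higher number from compound 1 to compound 4 (0.24 log units; within the scatter)). For the compounds shown here, compound 3 remains the only compound set apart, as the exchange of benzyl(methyl)amino for (2-methoxybenzyl)amino shows (a 6.2-fold lower number from compound 3 to compound 4 (0.79 log units; beyond the scatter)).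

Compound 3 differs from the others in both the methyl on the amine nitrogen and its unsubstituted ring, so the plain benzylamino group, with a hydrogen on that nitrogen, would be needed to separate the two. No measurement here gives a cause for any of these steps.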